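The compounds below may be only part of what the source reports. "The series", "measured", "known", "first", "only" and "open" are said of these compounds alone.

Measured in a functional assay on B16-F10 cells (Mus musculus) for antiproliferative activity, read by MTT assay, with a stated time of 48 h; on this read-out higher numbers stand for weaker inhibition and lower numbers for stronger inhibition:
- compound 1 `CC(=O)N1N=C(c2ccccc2)CC1c1ccc2c(c1)OCCO2`: 39500 nM
- compound 2 `COc1ccc(C2=NN(C(C)=O)C(c3ccc4c(c3)OCCO4)C2)cc1`: 31700 nM
- compound 3 `CC(=O)N1N=C(c2ccc(Br)cc2)CC1c1ccc2c(c1)OCCCO2`: 97000 nM

Compound 3 has the highest number of the three, and its gaps to compound 1 and compound 2 both lie beyond the scatter. Its core also differs from theirs. Compound 4 `COc1ccc(C2=NN(C(C)=O)C(c3ccc4c(c3)OCCCO4)C2)cc1` keeps the core of compound 3 and places methoxy in place of bromo on an aromatic carbon.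

Going by the values given here, no measured step replaces bromo. The closest evidence is a 1.2-fold lower number from compound 1 to compound 2 (0.10 log units; within the scatter), which brings in methoxy in place of hydrogen on the other core and stays within the scatter. Compound 2 differs from compound 3 in both the core and this group, so the gap between their values cannot be assigned to methoxy alone. Only a small shift toward a lower number is therefore expected in this assay, probably no step beyond the scatter. The expected change is a 1.5-fold lower number from compound 3 to compound 4 (0.17 log units; within the scatter). The estimate for compound 4 is 65000 nM, with an expected range from 28000 nM to 130000 nM.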

Compound 4, half-maximal inhibitory concentration: 85300 nM
Compound 4: the middle estimate sits 1.3-fold (0.12 log units) below what was measured; the range from low to high includes it.
By their numbers in this assay, from the lowest: compounds 2 and 1 (each within the scatter of the next); then compounds 4 and 3 (each within the scatter of the next).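

In this assay, replacing 4-bromophenyl with 4-methoxyphenyl on the core of compound 3 gives a 1.1-fold lower number from compound 3 to compound 4 (0.06 log units; within the scatter), so exchanging bromo for methoxy at this position produces no shift beyond the scatter. The earlier step at this position, a 1.2-fold lower number from compound 1 to compound 2 (0.10 log units; within the scatter), covered only methoxy in place of hydrogen on the other core, whereas this result extends the same outcome to a different group being replaced and to a second core. Nothing available explains why the number stays within the scatter for this change.

The compounds shown leave open whether a different group at this position, such as an amine or a carboxylic acid, would move the number beyond the scatter. On these data alone, how far the core alone shifts the number also remains open.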